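A few compounds are considered here, and "the series" means these few. Any claim that something is new, unique, unknown or untested is made for them only; others in the source may bear on it.

Compound 1 `O=S(=O)(Nc1ccc(-c2nc3ccccc3o2)cc1)c1ccccc1Cl` is the starting point. In an ADME assay on HEK293 cells (Homo sapiens) for cytotoxicity, read by resazurin assay, with a stated time of 48 h (on this read-out lower numbers stand for higher toxicity in this test and higher numbers for lower toxicity in this test), compound 1 gives > 100000 nM, which is a limit of the assay rather than a number. Two related compounds carry numbers in this assay: compound 2 `Cc1ccccc1S(=O)(=O)Nc1ccc2oc(-c3ccccc3)nc2c1` gives 57000 nM, and compound 3 `O=S(=O)(Nc1ccc2oc(-c3ccccc3)nc2c1)c1cccs1` gives 97000 nM. Putting thiophen-2-yl in place of 2-methylphenyl on a sulfonyl sulfur gave a 1.7-fold higher number from compound 2 to compound 3 (0.23 log units; within the scatter). Compound 4 `COc1ccc(Cl)cc1S(=O)(=O)Nc1ccc(-c2nc3ccccc3o2)cc1` is not yet measured; it differs from compound 1 by 5-chloro-2-methoxyphenyl in place of 2-chlorophenyl on a sulfonyl sulfur. Among the compounds with values here, the only measured step that exchanges the group on the sulfonyl sulfur is the one from compound 2 to compound 3, and that stayed within the scatter. Compound 1 itself sits at the limit of > 100000 nM in this assay, at which 1 of the 3 values shown sits, so there is no number from which a step could start. In this assay compound 4 is therefore expected to give about 100000 nM, between 40000 nM and 250000 nM. This estimate for compound 4 means a number no higher from compound 1 to compound 4 (the limit leaves the size open), a step expected to stay within the scatter, with a fair chance that only a limit is reported again.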

Compound 4, half-maximal cytotoxic concentration: 75000 nM
The estimate for compound 4 lay 1.3-fold (0.12 log units) above the measured number; the range from low to high includes it.
By their numbers in this assay, from the lowest: compounds 2, 4 and 3 (each within the scatter of the next). At a limit, above all of these: compound 1.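

Putting 5-chloro-2-methoxyphenyl in place of 2-chlorophenyl on a sulfonyl sulfur gave an at least 1.3-fold lower number from compound 1 to compound 4 (0.12 log units; that floor lies within the scatter) in this assay. This is the only exchange shown at this place on the core of compound 1, and it yields a measured number on that core, where the earlier compound offered only a limit. The true size of the step remains unknown, because it starts from a limit and not from a number: the limit of > 100000 nM in this assay, at which 1 of the 4 values shown sits.

The compounds shown do not separate the part played by the methoxy group from that of the chlorine within the entering group. They also leave open whether a group of another kind on the sulfonyl sulfur, such as an amine or a carboxylic acid, would move the number beyond the scatter.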